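This account rests on a few compounds, and the source may have more. Where it says the series, first, only, none or still open, it means among the compounds named here.

In an ADME assay on cells (Hepatocyte, Homo sapiens) for metabolic stability, read by LC-MS, with a stated time of 180 min, tested at 1 uM (on this read-out higher numbers stand for fast clearance and lower numbers for slow clearance), compound 2 `CC(C)(C(=O)O)c1nn(Cc2cn3cc(OCC4CC4)c(Cl)cc3n2)c2ccccc2c1=O` gives < 10 mL/min/kg, which is a limit and not a number. Compound 1 `O=C(O)Cc1nn(Cc2cn3cc(OCC4CC4)c(Cl)cc3n2)c2ccccc2c1=O` also gives only a limit, < 6.67 mL/min/kg. Compound 3 `CCC(C(=O)O)c1nn(Cc2cn3cc(OCC4CC4)c(Cl)cc3n2)c2ccccc2c1=O` carries 1-carboxypropyl in place of 1-carboxy-1-methylethyl on an aromatic carbon. Within the data shown here, the one measured step that bears on this change is a step that the two limits leave unreadable from compound 1 to compound 2, so it offers neither a size nor a direction, and nothing beyond the scatter is expected in this assay. The expected move is a step that the limit leaves unreadable from compound 2 to compound 3. The estimate for compound 3 is 6 mL/min/kg, with a range of 3 mL/min/kg to 12 mL/min/kg.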

Compound 3, clearance: < 8.34 mL/min/kg
Compound 3: only a limit was reported; the forecaster's own chance of this, stated with the estimate: 65%; the middle value lies beyond the limit too.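

In this assay compound 3 gives < 8.34 mL/min/kg, which is a limit. Among these compounds, compound 1 and compound 2 also give only limits, so no step among the three can be read. Going by these compounds, their actual clearance values and their order remain open.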